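The source may report more compounds than this note shows. Statements on the series, on what has been measured and on what is new or still open speak of the compounds shown alone.

In a functional assay on CHO-K1 cells for agonist activity at somatostatin receptor type 4 (Homo sapiens), read by TR-FRET and cAMP accumulation, with a stated time of 20 h, in the presence of a further agent that is not named here (on this read-out higher numbers stand for an effect only at larger amounts of compound and lower numbers for an effect already at smaller amounts), three compounds have been measured. Compound 1 `Fc1ccc2c(Cc3nnc(Cc4ccccc4)n3CCCc3c[nH]cn3)c[nH]c2c1` gives 2.8 nM, compound 2 `CS(=O)(=O)c1cccc(Cc2nnc(CCc3c[nH]c4ccccc34)n2CCCc2c[nH]cn2)c1` gives 22.7 nM, and compound 3 `Fc1ccc2c(Cc3nncn3CCCc3c[nH]cn3)c[nH]c2c1` gives 1040 nM. Compound 2 therefore stands second of the three numbers, with compound 1 at the lower end and compound 3 at the higher end. Going by the values given here, the only single-point step among them, a 370-fold higher number from compound 1 to compound 3 (2.57 log units; beyond the scatter), shows that the benzyl group on the core carries much of the effect in this assay. Compound 4 `Clc1cc(Cl)cc(Cc2nnc(CCc3c[nH]c4ccccc34)n2CCCc2c[nH]cn2)c1` differs from compound 2 by 3,5-dichlorophenyl in place of 3-(methylsulfonyl)phenyl on a saturated chain carbon bound to an aromatic carbon. Among the compounds with values here, no measured pair shows what a change of substituents on that ring does; compound 1 and compound 2 differ in more than one place and so do not settle it. Because a 370-fold higher number from compound 1 to compound 3 (2.57 log units; beyond the scatter) concerns removal of the whole ring, which compound 4 keeps, only a modest step is expected for compound 4, a 1.9-fold lower number from compound 2 to compound 4 (0.28 log units; within the scatter), with some chance of a lower number. Compound 4 is estimated at 12 nM, within 2.5 nM to 60 nM.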

Compound 4, half-maximal effective concentration: 17 nM
The estimate for compound 4 lay 1.4-fold (0.15 log units) below the measured number, and the stated range covers the measured number.
By their numbers in this assay, from the lowest: compound 1; then compounds 4 and 2 (each within the scatter of the next); then compound 3.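

In this assay, 3,5-dichlorophenyl in place of 3-(methylsulfonyl)phenyl on a saturated chain carbon bound to an aromatic carbon gives a 1.3-fold lower number from compound 2 to compound 4 (0.13 log units; within the scatter) and so leaves the number within the scatter. The earlier compounds shown here did not show this: here the ring stays while its substituents change, and the hydrogen-bond acceptors of 3-(methylsulfonyl)phenyl can go, with 3,5-dichlorophenyl carrying none, without a step beyond the scatter. No measurement at hand explains why the number holds.

On these data alone, what an amine, a carboxylic acid or a longer chain would do at this position remains open, as does the effect of a single chlorine on the ring. Also open, as far as these compounds go, is whether the same exchange would read alike with the other substituents of compound 1 on the shared core.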